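Cyclopropyl for Butyl on a Carbonyl Carbon

This account rests on a few compounds, and the source may have more. Where it says the series, first, only, none or still open, it means among the compounds named here.

In a functional assay on DU-145 cells (Homo sapiens) for inhibition, read by MTT assay, with a stated time of 24 h (a lower number here means a stronger inhibitor, a higher number a weaker inhibitor), compound 2 `C/C=C(\C)C(=O)O[C@@H]1[C@]2(OC(=O)CCCC)C=C3C4=CC(=O)O[C@@H](c5ccoc5)[C@]4(C)CC[C@@H]3[C@@]3(C)[C@H](C[C@]1(C)[C@H]3[C@@H](O)C(=O)OC)O2` gives 5200 nM and compound 1 `C/C=C(\C)C(=O)O[C@@H]1[C@]2(OC(=O)CCCC)C=C3C4=CC(=O)O[C@@H](c5ccoc5)[C@]4(C)CC[C@@H]3[C@@]3(C)[C@H](C[C@]1(C)[C@H]3[C@@H](OC(=O)CCCC)C(=O)OC)O2` gives 4200 nM and so the two stand within the scatter of each other. Among the compounds with values here, compound 3 `C/C=C(\C)C(=O)O[C@@H]1[C@]2(OC(=O)C3CC3)C=C3C4=CC(=O)O[C@@H](c5ccoc5)[C@]4(C)CC[C@@H]3[C@@]3(C)[C@H](C[C@]1(C)[C@H]3[C@@H](O)C(=O)OC)O2` carries cyclopropyl in place of butyl on a carbonyl carbon and no measured compound holds that group. Within the data shown here, the one measured step bears only indirectly: removing a different butylcarbonyl from compound 1 gave a 1.2-fold higher number from compound 1 to compound 2 (0.09 log units; within the scatter) and this suggests a modest response. The expected change is a 1.0-fold lower number from compound 2 to compound 3 (0.02 log units; within the scatter) and none beyond the scatter is expected in this assay. Compound 3 is estimated at 5000 nM within an expected range of 2400 nM to 10000 nM.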

Compound 3, half-maximal inhibitory concentration: > 100000 nM
Compound 3 was reported as a limit; the forecaster's own chance of this, stated with the estimate: 3%; at least 20-fold (1.30 log units) between middle value and limit.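

Cyclopropyl in place of butyl on this carbonyl carbon gives, in this assay, an at least 19-fold higher number from compound 2 to compound 3 (1.28 log units; beyond the scatter), so a swap of one small group here can decide whether the compound registers as an inhibitor at all. Within the data shown here, the only earlier step, made at a different butylcarbonyl, stayed within the scatter: a 1.2-fold higher number from compound 1 to compound 2 (0.09 log units; within the scatter). The result for compound 3 is a limit, not a number: the limit of > 100000 nM in this assay, at which 1 of the 3 values shown sits.

On these data alone, whether the loss follows the ring or the shorter carbon count stays open. A propyl chain or a cyclobutyl group on the same carbonyl carbon would help separate the two.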